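Three Limits at the Top, and a Bigger Amide Substituent

This account rests on a few compounds, and the source may have more. Where it says the series, first, only, none or still open, it means among the compounds named here.

Compound 1, `CCCCNC(=O)Nc1cc2nc(C3CCCCC3)[nH]c2cc1N(CC)CC`: in an ADME assay on Vero cells (Chlorocebus sabaeus) for cytotoxicity, read by resazurin assay, with a stated time of 3 days (a lower number here means a stronger inhibitor, a higher number a weaker inhibitor), compound 1 gives > 100 ug/mL, which is a limit of the assay, not a number.
Compound 2, `CCN(CC)c1cc2[nH]c(C3CCCCC3)nc2cc1NC(=O)c1cnccn1`: in this assay compound 2 gives > 100 ug/mL, again a limit.
Compound 3, `CCCOCC(=O)Nc1cc2nc(C3CCCCC3)[nH]c2cc1N(CC)CC`: in this assay compound 3 gives > 100 ug/mL, also a limit.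

All three compounds share the same core and differ only in the group attached to the carbonyl carbon of the amide. Within the data shown here, compound 3 stands where the other two stand, at the limit of > 100 ug/mL in this assay, at which 3 of the 3 values shown sit, so no compound can be placed above or below another on these numbers.

Compound 4, `CCN(CC)c1cc2[nH]c(C3CCCCC3)nc2cc1NC(=O)c1ccc(OC(F)(F)F)cc1`, has not yet been measured. It differs from compound 3 in one place: 4-(trifluoromethoxy)phenyl in place of propoxymethyl on a carbonyl carbon. The measured steps that touch this position are a step that the two limits leave unreadable from compound 1 to compound 2, a step that the two limits leave unreadable from compound 1 to compound 3 and a step that the two limits leave unreadable from compound 2 to compound 3. None of them has a readable size, so they give no ground for expecting a step in either direction in this assay, only a hint that changes at this carbonyl carbon have so far left the read-out at the limit.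

Compound 4 is therefore expected to land near 100 ug/mL, within a range of 40 ug/mL to 200 ug/mL. That estimate corresponds to an expected step of a number no higher from compound 3 to compound 4 (the limit leaves the size open), with a fair chance that the assay again returns only a limit.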

Compound 4, half-maximal inhibitory concentration: > 100 ug/mL
Compound 4: no number, only a limit (the forecaster's own chance of this, stated with the estimate: 65%); the middle value lies on the limit itself.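

Compound 4 gives only a limit in this assay, as do compound 1, compound 2 and compound 3, so none of the steps to compound 4 can be read: the limit of > 100 ug/mL in this assay, at which 4 of the 4 values shown sit. The compounds shown leave open where each true value lies beyond that limit, and whether any group on this carbonyl carbon would give a measurable number.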